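The source may report more compounds than this note shows. Statements on the series, on what has been measured and on what is new or still open speak of the compounds shown alone.

Measured compounds:
Compound 1 `COc1ccc(-n2cc(Cn3c(=O)oc4ccccc43)nn2)cc1` — in a functional assay on the whole organism (strain albino Wistar) for inhibition, with Rattus norvegicus as the target, read by paw edema, with stated times of 1 h and 3 h, at a dose of 0.05 mmol/kg by the oral route (on this read-out lower numbers stand for less inhibition and higher numbers for more inhibition at the one dose given (going by the name of the read-out)), compound 1 is reported as "active" (no number reported).
Compound 2 `Cc1ccc2c(c1)oc(=O)n2Cc1cn(-c2ccc(F)cc2)nn1` — in this assay compound 2 gives 81.4%.

Compound 1 stands without a single number: only a report of activity, so it cannot be placed against compound 2 on the numbers shown. Compound 2 carries the only quantitative read-out in the series, and the two compounds differ in more than one place, so no step can be read between them.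

Compound 3 `CCOc1ccc(-n2cc(Cn3c(=O)oc4ccccc43)nn2)cc1` differs from compound 1 by methyl in place of hydrogen on a saturated chain carbon bound to an oxygen on an aromatic ring. Among the compounds with values here, no pair of measured compounds shows this change, so its size cannot be taken from the series. The expectation is a step in this assay no larger than the usual scatter, with no direction assigned.

The estimate for compound 3 in this assay is 72%, with a range from 50% to 90%. Within the data shown here, this expectation rests on compound 2, which gives 81.4% as the only number in hand, and on compound 1 being reported as "active" (no number reported).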

Compound 3, a percentage reported as inhibition, in the whole organism at one dose (the size of the read-out at that dose, not a potency): "active" (no number reported)
No number was reported for compound 3; the estimate stays without a comparison.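

Compound 1 and compound 3 are both reported only as active in this assay without a number, so no step can be read for methoxy to ethoxy. No evidence on hand bears on this result. The compounds shown leave open the size and direction of that step, and where compound 1 and compound 3 stand against compound 2.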